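The source may hold more compounds than are shown below. What is called first, only, known or untested is meant among the compounds shown, and "the series" means these compounds.

Measured compounds:
compound 1 `COc1cc2oc(-c3cccc(NC(=O)c4ccccc4)c3)cc(=O)c2c(OC)c1OC`, 11700 nM
compound 2 `COc1cc2oc(-c3cccc(NC(=O)c4cccc(Br)c4)c3)cc(=O)c2c(OC)c1OC`, 10900 nM
compound 3 `COc1cc2oc(-c3cccc(NC(=O)c4ccc([N+](=O)[O-])cc4)c3)cc(=O)c2c(OC)c1OC`, 18800 nM

All three were tested in a functional assay on HepG2 cells (Homo sapiens) for inhibition, read by MTT assay; a lower number here means a stronger inhibitor of growth, a higher number a weaker inhibitor of growth. Compound 1 stands second highest of the three numbers; its nearest neighbour is compound 2, and the furthest is compound 3, yet both steps fall within the scatter, so no order among the three can be claimed.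

The unmeasured compound 4 `COc1ccc(C(=O)Nc2cccc(-c3cc(=O)c4c(OC)c(OC)c(OC)cc4o3)c2)cc1` differs from compound 1 by a single change: methoxy in place of hydrogen on an aromatic carbon.

Going by the values given here, two measured steps bear on this. Both alter the same phenyl ring of the benzamido group with a substituent on an aromatic carbon: a 1.1-fold lower number from compound 1 to compound 2 (0.03 log units; within the scatter) and a 1.6-fold higher number from compound 1 to compound 3 (0.21 log units; within the scatter). Neither leaves the scatter. The change to compound 4 places another substituent on that ring, so no step beyond the scatter is expected in this assay, in either direction; the range is set wider than the scatter because the entering group is not one already seen on this ring.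

For compound 4 the expected value in this assay is 12000 nM, with a likely range of 5000 nM to 28000 nM, which means an estimated step of a 1.0-fold higher number from compound 1 to compound 4 (0.01 log units; within the scatter).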

Compound 4, concentration for 50% growth inhibition: 22200 nM
Compound 4: the middle estimate sits 1.9-fold (0.27 log units) below what was measured; the measured number falls inside the stated range.
By their numbers in this assay, from the lowest: compounds 2, 1, 3 and 4 (each within the scatter of the next, the first and the last beyond it).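

In this assay, methoxy on the aromatic carbon para to a large group gives a 1.9-fold higher number from compound 1 to compound 4 (0.28 log units; within the scatter), and methoxy in place of nitro at that same place gives a 1.2-fold higher number from compound 3 to compound 4 (0.07 log units; within the scatter), so neither step separates these groups on this ring. The series now holds its first step beyond the scatter, a 2.0-fold higher number from compound 2 to compound 4 (0.31 log units; beyond the scatter), which is modest and links only the 3-bromophenyl and 4-methoxyphenyl amides, while compound 1 and compound 3 each remain within the scatter of both. Nothing at hand accounts for that gap.

Still open, as far as these compounds go, is how an amine, a carboxylic acid or a hydroxyl group on this ring would read in this assay, and whether a longer chain such as ethoxy in place of methoxy would stay within the scatter of compound 1. Also open, from the compounds shown here alone, is whether the small gap between the 3-bromophenyl and 4-methoxyphenyl amides would hold in repeated measurements or in cells other than HepG2.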